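This account rests on a few compounds, and the source may have more. Where it says the series, first, only, none or still open, it means among the compounds named here.

Within the data shown here, compound 1 `Cn1c(-c2noc(C3CCN(C(=O)NC4CCCCC4)CC3)n2)nc2ccccc21` and compound 2 `Cn1c(-c2noc(C3CCN(C(=O)NC4CCS(=O)(=O)CC4)CC3)n2)nc2ccccc21` are the two compounds measured so far in a functional assay on Shh Light II cells (Mus musculus) for inhibition, read by a luciferase reporter; a higher number here means a weaker inhibitor, a lower number a stronger inhibitor. Compound 1 gives 89 nM in this assay, and compound 2 gives 350 nM. Among the measured compounds shown here, compound 1 therefore stands with the lower of the two numbers; its only neighbour is compound 2, reached by a 3.9-fold higher number from compound 1 to compound 2 (0.59 log units; beyond the scatter), where 1,1-dioxothian-4-yl takes the place of cyclohexyl on the amide-type nitrogen.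

Compound 3 `O=C(NC1CCCCC1)N1CCC(c2nc(-c3ccc4ccccc4n3)no2)CC1` has not been measured. It keeps the cyclohexyl urea of compound 1 and alters the aromatic end: quinolin-2-yl in place of 1-methyl-1H-benzimidazol-2-yl on an aromatic carbon. For the measured compounds named here, the single measured step, a 3.9-fold higher number from compound 1 to compound 2 (0.59 log units; beyond the scatter), concerns the amide-type nitrogen and not the aromatic carbon of the five-membered ring that bears the change, so no measured step bears directly on this exchange. The series gives no basis for a direction, and the expectation for this assay is a step of no clear direction, most likely within the scatter, with a broad range on either side. The step implied by this estimate, a 1.6-fold higher number from compound 1 to compound 3 (0.20 log units; within the scatter), is expected to stay near the value of compound 1. Compound 3 is therefore estimated at 140 nM, with a range from 35 nM to 600 nM.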

Compound 3, half-maximal inhibitory concentration: 57 nM
Estimate against measurement, compound 3: 2.5-fold (0.39 log units) above; low and high end bracket the measured number.
By their numbers in this assay, from the lowest: compounds 3 and 1 (each within the scatter of the next); then compound 2.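

In this assay, among these compounds, quinolin-2-yl in place of 1-methyl-1H-benzimidazol-2-yl on the aromatic carbon gives a 1.6-fold lower number from compound 1 to compound 3 (0.19 log units; within the scatter) and so leaves compound 1 and compound 3 indistinguishable, the first reading on this end of the molecule. This contrasts with the step at the amide-type nitrogen, a 3.9-fold higher number from compound 1 to compound 2 (0.59 log units; beyond the scatter), so within these three compounds only the change at the urea end lies beyond the scatter, while here a five-membered aromatic ring with 2 hetero atoms gives way to a six-membered aromatic ring with 1 hetero atom without a readable difference. No measurement in hand explains why the two groups read alike.

The compounds shown leave open how a single aromatic ring such as phenyl or pyridin-2-yl would read on this carbon, and whether a quinolin-2-yl bearing a methoxy group would stay within the same range. They also leave open whether quinolin-2-yl paired with the 1,1-dioxothian-4-yl urea would follow the step seen from the cyclohexyl urea, since the two changes appear here only separately.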